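This account rests on a few compounds, and the source may have more. Where it says the series, first, only, none or still open, it means among the compounds named here.

Measured compounds in an ADME assay on Raji cells (Homo sapiens) for cytotoxicity, read by CellTiter-Glo and resazurin assay, with a stated time of 72 h; on this read-out higher numbers stand for an effect only at larger amounts of compound and lower numbers for an effect already at smaller amounts:
Compound 1 `CC(C)N(Cc1cccc(OCCCCCC(=O)O)c1)C(=O)c1ccc(-c2cccc(N(C)C)c2)cc1` gives > 26000 nM, a limit of the assay.
Compound 2 `CC(=O)Nc1cccc(-c2ccc(C(=O)N(Cc3cccc(OCCCCCC(=O)O)c3)C(C)C)cc2)c1` gives > 26000 nM, a limit of the assay.
Compound 3 `CCOC(=O)CCCCCOc1cccc(CN(C(=O)c2ccc(-c3ccc4ccccc4c3)cc2)C(C)C)c1` gives > 26000 nM, a limit of the assay.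

Compound 3 stands at the limit of > 26000 nM in this assay, at which 3 of the 3 values shown sit; no number is known for it, only that limit. Within the data shown here, the same holds for the other two compounds, so the one step that can be traced among them, a step that the two limits leave unreadable from compound 1 to compound 2, is unreadable in size and direction, and no comparison yields a measured change to lean on.

The step to compound 4 `CCOC(=O)CCCCCOc1cccc(CN(C(=O)c2ccc(-c3cccc(OC(F)(F)F)c3)cc2)C(C)C)c1` is 3-(trifluoromethoxy)phenyl in place of naphthalen-2-yl on an aromatic carbon. Among the measured compounds shown here, no measured step bears on this change: the only traced step concerns a different position and itself sits between two limits. With every value in the series at the limit, compound 4 is expected to remain at or near that limit as well, with no step beyond the scatter foreseen. The step expected is therefore a step that the limit leaves unreadable from compound 3 to compound 4. For compound 4 the estimate is 30000 nM, with a range from 13000 nM to 70000 nM, and a large chance that only a limit is reported.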

Compound 4, half-maximal effective concentration: > 26000 nM
Compound 4: no number, only a limit; the forecaster's own chance of this, stated with the estimate: 85%; the middle value lies beyond the limit too.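

No new step can be read between compound 3 and compound 4 in this assay, since neither has a number: the limit of > 26000 nM in this assay, at which 4 of the 4 values shown sit.

The compounds shown leave open at what concentration any of them would take effect in this assay, and whether 3-(trifluoromethoxy)phenyl in place of naphthalen-2-yl changes that concentration.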